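A Sulfonyl Thiophene Replaces the Benzofuran Amide

The source may hold more compounds than are shown below. What is called first, only, known or untested is meant among the compounds shown, and "the series" means these compounds.

Compound 1 `CCCCCCCCNC(=O)[C@@H](NC(=O)c1cc2ccccc2o1)[C@@H](C)O` and compound 2 `CCCCCCCCCCCCCCCCCCNC(=O)[C@@H](NC(=O)c1cc2ccccc2o1)[C@@H](C)O` share one core and differ only in the length of a chain. In a functional assay on SW-620 cells (Homo sapiens) for cytotoxicity, read by MTT assay, with a stated time of 48 h (a lower number here means a stronger inhibitor, a higher number a weaker inhibitor), compound 1 gives 200000 nM. For compound 2 this assay reports only a limit, > 200000 nM. The step of a number no lower from compound 1 to compound 2 (the limit leaves the size open) thus shows no gain in potency, and because of the limit of > 200000 nM in this assay, at which 1 of the 2 values shown sits, its true size cannot be read. Compound 3 `CCCCCCCCCCCCCCCCCCNC(=O)[C@@H](NS(=O)(=O)c1cccs1)[C@@H](C)O` has not yet been measured; it differs from compound 2 by (thiophen-2-yl)sulfonyl in place of (1-benzofuran-2-yl)carbonyl on an amine nitrogen. Among the measured compounds shown here, no measured step touches this part of the molecule; the single step available concerns the chain and ends at the limit. Compound 2 already sits at the edge of what this assay can report. Compound 3 is therefore expected to stay near that edge, a step of a number no higher from compound 2 to compound 3 (the limit leaves the size open) of no clear direction beyond the scatter. For compound 3 in this assay the estimated value is 200000 nM, with a range from 70000 nM to 500000 nM.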

Compound 3, half-maximal inhibitory concentration: > 200000 nM
Compound 3 ended at the assay's limit; the forecaster's own chance of this, stated with the estimate: 60%; the middle value sits exactly at the limit.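

The step from compound 2 to compound 3 cannot be read, because both compounds end at a limit rather than a number: the limit of > 200000 nM in this assay, at which 2 of the 3 values shown sit.

The compounds shown leave open whether (thiophen-2-yl)sulfonyl in place of (1-benzofuran-2-yl)carbonyl changes the result in this assay at all, and in which direction.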